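The source may report more compounds than this note shows. Statements on the series, on what has been measured and on what is new or still open speak of the compounds shown alone.

Measured so far:
- compound 1 `O=C(c1ccc(Cl)s1)c1nc(NCc2cccnc2)nc2ccsc12`: in a functional assay on CHO-K1 cells for antagonist activity at adenosine receptor A2b (Homo sapiens), read by FLIPR and calcium flux (on this read-out lower numbers stand for stronger inhibition and higher numbers for weaker inhibition), compound 1 gives 487 nM
- compound 2 `O=C(c1cncs1)c1nc(NCc2cccnc2)nc2ccsc12`: in this assay compound 2 gives 148 nM
- compound 3 `O=C(c1cccnc1)c1nc(NCc2cccnc2)nc2ccsc12`: in this assay compound 3 gives 109 nM

Compound 3 has the lowest of the three numbers. Its gap to compound 2 is within the scatter (a 1.4-fold lower number from compound 2 to compound 3 (0.13 log units; within the scatter)), so these two cannot be ordered; its gap to compound 1 is beyond it (a 4.5-fold lower number from compound 1 to compound 3 (0.65 log units; beyond the scatter)). The step from compound 1 to the thiazolyl analogue is likewise modest (a 3.3-fold lower number from compound 1 to compound 2 (0.52 log units; beyond the scatter)).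

Compound 4 `O=C(c1ccncc1)c1nc(NCc2cccnc2)nc2ccsc12` is not yet measured. It differs from compound 3 by pyridin-4-yl in place of pyridin-3-yl on a carbonyl carbon. Among the compounds with values here, no measured step swaps one pyridinyl for another. The closest guide is the exchange of one heteroaryl on the carbonyl carbon for another between compound 2 and compound 3, which stayed within the scatter, while the two steps away from the chlorothiophene of compound 1 were only modest. A move of the ring nitrogen alone is therefore not expected to shift the number beyond the scatter. The expected step in this assay is a 1.2-fold higher number from compound 3 to compound 4 (0.08 log units; within the scatter), within the scatter. Compound 4 is estimated at 130 nM, with a range of 50 nM to 350 nM.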

Compound 4, half-maximal inhibitory concentration: 869 nM
Beside the measured number, compound 4's estimate is 6.7-fold (0.83 log units) below it; measured number outside the range, above it.
By their numbers in this assay, from the lowest: compounds 3 and 2 (each within the scatter of the next); then compounds 1 and 4 (each within the scatter of the next).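

In this assay the place of the ring nitrogen alone matters on this carbonyl carbon: with the same atoms and the same counted features, pyridin-4-yl in place of pyridin-3-yl gives an 8.0-fold higher number from compound 3 to compound 4 (0.90 log units; beyond the scatter) and is the largest step in the set so far. Pyridin-4-yl also separates from the thiazolyl group, with a 5.9-fold higher number from compound 2 to compound 4 (0.77 log units; beyond the scatter) as the step, but not from the chlorothiophene, with a 1.8-fold higher number from compound 1 to compound 4 (0.25 log units; within the scatter) as the step. Ring class alone therefore does not sort this position: the two pyridinyl isomers, compound 3 and compound 4, fall on opposite sides of a gap beyond the scatter.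

No measurement here bears on why moving the ring nitrogen has this effect.

Open, as far as these compounds go, is how pyridin-2-yl, plain phenyl, or an amine or methoxy group on the pyridin-3-yl ring would read out at this position.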